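This account rests on a few compounds, and the source may have more. Where it says the series, first, only, none or still open, it means among the compounds named here.

Measured so far in a functional assay on C8166 cells (Homo sapiens) for cytotoxicity, read by MTT assay; on this read-out lower numbers stand for higher toxicity in this test and higher numbers for lower toxicity in this test:
compound 1 `Cc1cccc(C(=O)Nc2cc(Cl)ccc2OCC(=O)Nc2ccc(S(N)(=O)=O)cc2C)c1` gives 52900 nM;
compound 2 `Cc1cc(S(N)(=O)=O)ccc1NC(=O)COc1ccc(Cl)cc1NC(=O)c1cccc([N+](=O)[O-])c1` gives 58800 nM;
compound 3 `COc1ccc(C(=O)Nc2cc(Cl)ccc2OCC(=O)Nc2ccc(S(N)(=O)=O)cc2C)cc1` gives 69500 nM.

Compound 1 gives the lowest of the three numbers, yet all three sit within the scatter of one another: a 1.1-fold higher number from compound 1 to compound 2 (0.05 log units; within the scatter), a 1.3-fold higher number from compound 1 to compound 3 (0.12 log units; within the scatter), a 1.2-fold higher number from compound 2 to compound 3 (0.07 log units; within the scatter).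

Compound 4 `Cc1cc(S(N)(=O)=O)ccc1NC(=O)COc1ccc(Cl)cc1NC(=O)c1cc(Cl)cc(C#N)c1` is still to be measured in this assay. Against compound 1 it shows (3-chloro-5-cyanophenyl in place of 3-methylphenyl on a carbonyl carbon). Among the compounds with values here, the steps that bear on this are the two that also exchange the group on that carbonyl carbon, a 1.3-fold higher number from compound 1 to compound 3 (0.12 log units; within the scatter) and a 1.2-fold higher number from compound 2 to compound 3 (0.07 log units; within the scatter), plus the ring-substituent exchange a 1.1-fold higher number from compound 1 to compound 2 (0.05 log units; within the scatter); none of them moved beyond the scatter. The expected step is therefore a 1.0-fold higher number from compound 1 to compound 4 (0.02 log units; within the scatter), with no direction beyond the scatter. Compound 4 is accordingly estimated at 55000 nM, within 28000 nM to 110000 nM.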

Compound 4, half-maximal cytotoxic concentration: 131000 nM
For compound 4 the middle estimate is 2.4-fold (0.38 log units) below the measured one, outside the stated range (above it).
By their numbers in this assay, from the lowest: compounds 1, 2, 3 and 4 (each within the scatter of the next, the first and the last beyond it).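

Within the data shown here, on the carbonyl carbon, 3-chloro-5-cyanophenyl gives the first steps beyond the scatter, both modest and towards lower toxicity in this assay: a 2.5-fold higher number from compound 1 to compound 4 (0.39 log units; beyond the scatter) and a 2.2-fold higher number from compound 2 to compound 4 (0.35 log units; beyond the scatter). Against 4-methoxyphenyl the difference stays within the scatter, with a 1.9-fold higher number from compound 3 to compound 4 (0.28 log units; within the scatter), so compound 3 goes against a clear separation of compound 4 from the other groups. Nothing measured here accounts for these steps.

On these data alone, whether the chlorine or the nitrile carries the steps stays open, as the two enter together. As far as these compounds go, how a phenyl ring bearing an amine or a carboxylic acid would read also stays open.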